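The source may hold more compounds than are shown below. What is called first, only, known or untested is meant among the compounds shown, and "the series" means these compounds.

Measured compounds:
- Compound 1 `COC(=O)c1ccc(-c2cnc(C(=O)CCCCCCc3ccccc3)o2)cc1` gives 40 nM in an assay (Rattus norvegicus) for inhibition of Fatty-acid amide hydrolase 1 (Homo sapiens); a lower number here means a stronger inhibitor, a higher number a weaker inhibitor.
- Compound 2 `O=C(CCCCCCc1ccccc1)c1ncc(-c2ccc(O)cc2)o1` gives 140 nM in this assay.
- Compound 3 `O=C(CCCCCCc1ccccc1)c1ncc(-c2cc(C(F)(F)F)ccn2)o1` gives 3.5 nM in this assay.

All three share the same core, a seven-carbon chain ending in a phenyl ring attached through a carbonyl to a five-membered aromatic ring, and differ only in the group on that ring. Compound 2 stands highest of the three numbers, that is, it is the weakest inhibitor: compound 1 sits a 3.5-fold higher number from compound 1 to compound 2 (0.54 log units; beyond the scatter) away in the other direction, and compound 3 sits furthest, with a far lower number still.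

Compound 4 `CC(=O)c1cnc(C(=O)CCCCCCc2ccccc2)o1` is the next compound to be measured. It differs from compound 2 as follows: acetyl in place of 4-hydroxyphenyl on an aromatic carbon. For the measured compounds named here, the only measured step, a 3.5-fold higher number from compound 1 to compound 2 (0.54 log units; beyond the scatter), changes a substituent on the aryl ring but keeps the ring itself; it shows that the group on that ring matters at a modest scale. Going by the values given here, no measured pair shows what happens when the whole six-membered ring is removed and a small acetyl is put in its place, so the expectation rests on that gap alone. Since every measured compound carries a six-membered aromatic ring at this position, losing it is expected to move the number further upward, beyond the scatter, by about a 3.6-fold higher number from compound 2 to compound 4 (0.55 log units; beyond the scatter). Compound 4 is therefore estimated at 500 nM in this assay, with a range from 100 nM to 2500 nM.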

Compound 4, inhibition constant: 2 nM
Beside the measured number, compound 4's estimate is 250-fold (2.40 log units) above it; the whole stated range lies above it.
By their numbers in this assay, from the lowest: compounds 4 and 3 (each within the scatter of the next); then compound 1; then compound 2.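

For the compounds shown here, putting acetyl in place of 4-hydroxyphenyl on this aromatic carbon, next to the ring oxygen, gives a 70-fold lower number from compound 2 to compound 4 (1.85 log units; beyond the scatter) in this assay, so a six-membered aromatic ring is not needed here for a low number, something the earlier compounds, which all carry such a ring at this position, could not show. The change removes a ring and the hydrogen-bond donor and leaves fewer heavy atoms, yet compound 3 at 3.5 nM and compound 4 at 2 nM lie within the scatter of each other, so a small group without a ring and a large group with one both reach this range. Nothing measured here explains why the swap has such a large effect.

The compounds shown leave open whether the carbonyl of the acetyl matters or whether any small group would do, which a methyl, a carboxylic acid, a methyl ester or a primary amide on the same carbon would begin to separate. They also leave open whether the acetyl keeps its effect with a shorter or longer chain in place of the one in the shared core.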